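This account rests on a few compounds, and the source may have more. Where it says the series, first, only, none or still open, it means among the compounds named here.

For the measured compounds named here, in a functional assay on HL-60 cells (Homo sapiens) for inhibition, read by CCK-8 assay, with a stated time of 48 h (on this read-out lower numbers stand for stronger inhibition and higher numbers for weaker inhibition), compound 2 `O=S(=O)(NCCNC(=S)Nc1cc(C(F)(F)F)cc(C(F)(F)F)c1)c1ccc(-c2ccccc2OCc2ccccc2)s1` gives 2100 nM, the only true number so far. Compound 1 `O=S(=O)(NCCNC(=S)Nc1cc(C(F)(F)F)cc(C(F)(F)F)c1)c1ccc(-c2ccccc2OCc2cccc(O)c2)s1` reads > 50000 nM, and that value is a limit of the assay, not a number. The next compound to consider is compound 3 `O=S(=O)(NCCNC(=S)Nc1cc(C(F)(F)F)cc(C(F)(F)F)c1)c1ccc(-c2ccccc2Oc2ccc(O)c(O)c2)s1`, which differs from compound 2 by 3,4-dihydroxyphenyl in place of benzyl on an oxygen on an aromatic ring. The benzyl group is replaced, so the comparison is not exact, but one measured step bears on it. That step is large: an at least 23-fold lower number from compound 1 to compound 2 (1.37 log units; beyond the scatter), with hydrogen in place of hydroxy on an aromatic carbon. Compound 3 gains hydroxy groups, the reverse direction of that step, so a clearly higher number is expected in this assay, though a single step is thin support. The expected change is a 7.1-fold higher number from compound 2 to compound 3 (0.85 log units; beyond the scatter). For compound 3 the estimate is 15000 nM, with an expected range from 3000 nM to 60000 nM.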

Compound 3, half-maximal inhibitory concentration: 18300 nM
Estimate against measurement, compound 3: 1.2-fold (0.09 log units) below; the range from low to high includes it.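

Until now only one hydroxy on the benzyl ring had been varied at this position. Here the whole group on the oxygen changes, and in this assay 3,4-dihydroxyphenyl in place of benzyl gives an 8.7-fold higher number from compound 2 to compound 3 (0.94 log units; beyond the scatter). Set against the 3-hydroxybenzyl group, the same 3,4-dihydroxyphenyl gives an at least 2.7-fold lower number from compound 1 to compound 3 (0.43 log units; beyond the scatter), so among these three compounds, both that carry hydroxy groups read weaker than compound 2, but not to the same degree. The value of compound 1 is a limit of the assay, not a number: the limit of > 50000 nM in this assay, at which 1 of the 3 values shown sits.

The swap to 3,4-dihydroxyphenyl changes the linking carbon and the hydroxy groups at once, and the compounds shown do not separate the two. Also open, going by these compounds, is how an amine or a carboxylic acid on this ring would read.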